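This account rests on a few compounds, and the source may have more. Where it says the series, first, only, none or still open, it means among the compounds named here.

Measured compounds and their values:

- compound 1, `COc1ccccc1C(=O)/C=C/c1ccc2c(c1)B(O)OC2`: 2600 nM
- compound 2, `COc1cccc(C(=O)/C=C/c2ccc3c(c2)B(O)OC3)c1`: 2600 nM
- compound 3, `COCOc1ccccc1C(=O)/C=C/c1ccc2c(c1)B(O)OC2`: 6500 nM

All three were tested in a functional assay on SK-OV-3 cells (Homo sapiens) for cytotoxicity, read by MTT assay, with a stated time of 48 h; a lower number here means a stronger inhibitor, a higher number a weaker inhibitor. In this assay compound 1 gives 2600 nM, and compound 2 gives 2600 nM; these two stand level at the digits shown, so no order between them can be read. Compound 1 and compound 2 share the same atoms joined differently, and the difference between their two cores is not broken down here.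

Compound 3 differs from compound 1 in one place:

methoxy in place of hydrogen on a saturated chain carbon bound to an oxygen on an aromatic ring

This change gives a 2.5-fold higher number from compound 1 to compound 3 (0.40 log units; beyond the scatter), a modest loss of potency that lies beyond the usual scatter.

The unmeasured compound 4, `COCOc1cccc(C(=O)/C=C/c2ccc3c(c2)B(O)OC3)c1`, carries the same change relative to compound 2:

methoxy in place of hydrogen on a saturated chain carbon bound to an oxygen on an aromatic ring

The place of the change is described in the same words for both pairs, so this is the same change, seen for the second time in this set. Going by the values given here, with only one earlier example, the expectation rests on it alone. Because compound 1 to compound 3 gave a 2.5-fold higher number from compound 1 to compound 3 (0.40 log units; beyond the scatter), a step of similar size is expected from compound 2 to compound 4, namely a 2.5-fold higher number from compound 2 to compound 4 (0.40 log units; beyond the scatter). Compound 4 is therefore estimated at 6500 nM in this assay, with a plausible range from 2600 nM to 16000 nM.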

Compound 4, half-maximal inhibitory concentration: 11700 nM
Compound 4: middle estimate off by 1.8-fold (0.26 log units), on the low side; the range from low to high includes it.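

In this assay, the change again goes with a loss of potency, giving a 4.5-fold higher number from compound 2 to compound 4 (0.65 log units; beyond the scatter), so the direction seen on the core of compound 1 also appears on the core of compound 2. Set side by side, the two steps cannot be told apart in size: the same change on two cores in this assay, a 2.5-fold higher number (0.40 log units; beyond the scatter) from compound 1 to compound 3 and a 4.5-fold higher number (0.65 log units; beyond the scatter) from compound 2 to compound 4, 1.8-fold (0.26 log units) apart, within the scatter of two such steps. Going by these compounds alone, the change therefore carries across these two cores, but this rests on only two pairs in a single test, and it shows neither that the second step is truly larger than the first, nor why the number rises, nor that the same would hold on any other core.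

The compounds shown leave open what other groups would do in the same place, on a saturated chain carbon bound to an oxygen on an aromatic ring: a longer chain such as ethyl or propyl, an amine or a carboxylic acid might each give a different result. They also leave open whether the step from methoxy to methoxymethoxy would keep its direction and size on a third core, or in any test other than this assay.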